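A few compounds are considered here, and "the series" means these few. Any claim that something is new, unique, unknown or untested is made for them only; others in the source may bear on it.

Working notes on the series. In a functional assay on L1210 cells (Mus musculus) for antiproliferative activity (a higher number here means a weaker inhibitor, a lower number a stronger inhibitor), compound 1 `CCn1cc(-c2nnc(SCc3nnc(-c4ccc(F)cc4)o3)[nH]2)c(=O)c2cc(F)c(N3CCN(C)CC3)cc21` gives 3800 nM, and compound 2 `CCn1cc(-c2nc(SCc3nnc(-c4ccc(F)cc4)o3)n(CN(C)C)n2)c(=O)c2cc(F)c(N3CCN(C)CC3)cc21` gives 1500 nM. Compound 1 holds the higher of these two numbers, and its gap to compound 2 lies beyond the scatter. Compound 3 `CCn1cc(-c2nnc(SCc3nnc(-c4ccccc4OC)o3)[nH]2)c(=O)c2cc(F)c(N3CCN(C)CC3)cc21`, not yet measured, keeps the core of compound 1 and differs at one place, an aromatic carbon of the five-membered aromatic ring with 2 nitrogen and 1 oxygen: 2-methoxyphenyl in place of 4-fluorophenyl on an aromatic carbon. There, 2-methoxyphenyl stands in place of 4-fluorophenyl. Going by the values given here, no measured pair shows a change at this place, so the expectation has little direct support. In this assay, no step beyond the scatter is expected: the estimated step is a 1.3-fold lower number from compound 1 to compound 3 (0.10 log units; within the scatter). Compound 3 is expected at 3000 nM, with an estimated range from 1000 nM to 9000 nM.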

Compound 3, half-maximal inhibitory concentration: 3800 nM
The estimate for compound 3 lay 1.3-fold (0.10 log units) below the measured number; low and high end bracket the measured number.
By their numbers in this assay, from the lowest: compound 2; then compounds 1 and 3 (each within the scatter of the next).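

In this assay, going by these compounds alone, the first change at the aromatic carbon of the five-membered aromatic ring with 2 nitrogen and 1 oxygen gives no change at the digits printed from compound 1 to compound 3 (within the scatter). Within the data shown here, compounds 1 and 2 both carry 4-fluorophenyl, so only this step reads the place directly. Here, 2-methoxyphenyl, with 8 heavy atoms against 7 and 1 hydrogen-bond acceptor against 0, is tolerated as a replacement for 4-fluorophenyl on the core of compound 1, with the number staying within the scatter.

The compounds shown leave open whether an amine, a carboxylic acid or a longer alkyl chain at this place would move the number beyond the scatter. No measurement shown gives a reason for this result.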